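The source may hold more compounds than are shown below. What is called first, only, known or untested is meant among the compounds shown, and "the series" means these compounds.

Measured in a functional assay on NT2 cells (Homo sapiens) for inhibition; on this read-out lower numbers stand for stronger inhibition and higher numbers for weaker inhibition:
- compound 1 `CC[C@@H](C(=O)N[C@@H](CC(=O)O)C(=O)CSCc1ccccc1)n1cccc(NC(=O)[C@H](CC(=O)O)NC(C)=O)c1=O`: 5.2 nM
- compound 2 `CCC(C(=O)N[C@@H](CC(=O)O)C(=O)CSCc1ccccc1)n1ccnc(NCC2COc3ccccc3O2)c1=O`: 30 nM
- compound 3 `CCC(C(=O)N[C@@H](CC(=O)O)C(=O)CNCN1CCCCC1)n1cc(C(C)(C)C)nc(NCc2nonc2C)c1=O`: 0.29 nM

Compound 2 has the highest number of the three and so the weakest inhibition in this small set. Its gaps to compound 1 and to compound 3 both lie beyond the usual scatter, and the gap to compound 3 is the wider.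

Next in the series is compound 4 `CCC(C(=O)N[C@@H](CC(=O)O)C(=O)CSCc1ccccc1)n1ccnc(NCCCOC)c1=O`, still to be measured in this assay. Relative to compound 2 the change is 2-methoxyethyl in place of 2,3-dihydro-1,4-benzodioxin-2-yl on a saturated chain carbon bound to a nitrogen on an aromatic ring. The rest of the structure stays the same.

Among the measured compounds shown here, no two measured compounds differ in only one place, so the series offers no direct measure of what this change does. The spread among compounds 1, 2 and 3 cannot be assigned to any single group. For the measured compounds named here, the only firm anchor is compound 2 at 30 nM, and the range is kept wide for that reason.

No step beyond the scatter is expected, with a slight lean towards weaker inhibition: the estimated step is a 1.3-fold higher number from compound 2 to compound 4 (0.12 log units; within the scatter). For compound 4 the estimated value is 40 nM, with an expected range of 12 nM to 130 nM.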

Compound 4, half-maximal inhibitory concentration: > 10 nM
Compound 4 gave a limit, no number; the forecaster's own chance of this, stated with the estimate: 2%; the middle value is on the limit's open side.
By their numbers in this assay, from the lowest: compound 3; then compound 1; then compound 2.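

In this assay compound 4 gives > 10 nM as a limit and not a number. Among the compounds shown here, no step from compound 2 to compound 4 can be read from this result. Going by these compounds, it remains open how inhibition with the (3-methoxypropyl)amino group of compound 4 compares with that of the ((2,3-dihydro-1,4-benzodioxin-2-yl)methyl)amino group of compound 2.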